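The source may hold more compounds than are shown below. What is called first, only, known or untested is meant among the compounds shown, and "the series" means these compounds.

For the measured compounds named here, compound 3, `Cn1ccc2ccc(-c3cc(Nc4cnccc4C(=O)NCc4cncnc4)cc4nccnc34)cc21`, is one of three compounds measured in an assay on lysate for inhibition of 6-phosphofructo-2-kinase/fructose-2,6-bisphosphatase 3 (Homo sapiens), with stated times of 0.5 min and 45 min; a higher number here means a weaker inhibitor, a lower number a stronger inhibitor. Compound 3 gives 49500 nM. Compound 1, `Cn1ccc2ccc(-c3cc(Nc4ccccc4S(N)(=O)=O)cc4nccnc34)cc21`, gives 37600 nM, a number within the usual scatter of that of compound 3. Compound 2, `Cn1ccc2ccc(-c3cc(Nc4ccccc4S(=O)(=O)N4CCOCC4)cc4nccnc34)cc21`, gives 2640 nM, which lies beyond the scatter from compound 3. Going by the values given here, the one step measured so far, a 14-fold lower number from compound 1 to compound 2 (1.15 log units; beyond the scatter), concerns the sulfonyl group and not the amide side chain, so it does not bear directly on the next change. Compound 4, `CN1CCC(CNC(=O)c2ccncc2Nc2cc(-c3ccc4ccn(C)c4c3)c3nccnc3c2)C1`, differs from compound 3 by 1-methylpyrrolidin-3-yl in place of pyrimidin-5-yl on a saturated chain carbon bound to an amide-type nitrogen. Among the compounds with values here, with no measured step at this place, no change beyond the scatter is expected, and compound 4 is estimated at 40000 nM, from 10000 nM to 150000 nM, a step of a 1.2-fold lower number from compound 3 to compound 4 (0.09 log units; within the scatter) from compound 3.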

Compound 4, half-maximal inhibitory concentration: 24000 nM
Beside the measured number, compound 4's estimate is 1.7-fold (0.22 log units) above it; low and high end bracket the measured number.
By their numbers in this assay, from the lowest: compound 2; then compounds 4, 1 and 3 (each within the scatter of the next, the first and the last beyond it).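

For the compounds shown here, replacing the aromatic pyrimidin-5-yl with the non-aromatic 1-methylpyrrolidin-3-yl gives the first measured change on this amide side chain (a 2.1-fold lower number from compound 3 to compound 4 (0.31 log units; beyond the scatter)). This modest step lies only just beyond the scatter, so at this place one six-membered aromatic ring can give way to a five-membered saturated ring with little change in the number. Nothing measured here explains the step.

Still open, on these data alone, is whether the ring nitrogen or its methyl matters. A cyclopentyl ring or a pyrrolidine without the methyl, on the same chain carbon, would separate these two parts of the change.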